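A few compounds are considered here, and "the series" means these few. Any claim that something is new, unique, unknown or untested is made for them only; others in the source may bear on it.

Three compounds have been measured in an assay on membranes from brain (Cavia porcellus) for binding affinity to Sigma non-opioid intracellular receptor 1 (Homo sapiens); a higher number here means a weaker inhibitor, a lower number a stronger inhibitor:
compound 1 `c1ccc2c(c1)CCCC2CCCN1CCN(C2CCCCC2)CC1`, 0.61 nM;
compound 2 `COc1ccc2c(c1)C(CCCN1CCN(C3CCCCC3)CC1)CCC2`, 9.04 nM;
compound 3 `c1ccc2c(c1)CCCC2CCCCCN1CCN(C2CCCCC2)CC1`, 1.45 nM.

Compound 2 differs from compound 1 in one place, (methoxy in place of hydrogen on an aromatic carbon), and this single change gave a 15-fold higher number from compound 1 to compound 2 (1.17 log units; beyond the scatter). How the core of compound 3 differs from that of compound 1 is not broken down here; in this assay compound 3 stands between the other two, beyond the scatter from each of them.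

Compound 4 `COc1cccc2c1CCCC2CCCCCN1CCN(C2CCCCC2)CC1` has not yet been measured. It differs from compound 3 in one place, (methoxy in place of hydrogen on an aromatic carbon). This is the same kind of change as that from compound 1 to compound 2, but not the same: in compound 4 the methoxy sits ortho to a fused ring and meta to a fused ring, whereas in compound 2 it sits meta to a fused ring and para to a fused ring. Among the measured compounds shown here, since the one precedent gave a 15-fold higher number from compound 1 to compound 2 (1.17 log units; beyond the scatter), the step is expected to be a 5.5-fold higher number from compound 3 to compound 4 (0.74 log units; beyond the scatter), a rise, though the shift in place leaves its size uncertain. For compound 4 the expected value in this assay is 8 nM, likely between 2.5 nM and 30 nM.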

Compound 4, inhibition constant: 1.52 nM
Estimate against measurement, compound 4: 5.3-fold (0.72 log units) above, outside the stated range (below it).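

In this assay, methoxy in place of hydrogen on an aromatic carbon gave a 1.0-fold higher number from compound 3 to compound 4 (0.02 log units; within the scatter), so on this core the change made no difference that stands beyond the scatter. Set beside the earlier step, the same kind of change did not carry over from one core to the other at the same size: the same change on two cores in this assay, a 15-fold higher number (1.17 log units; beyond the scatter) from compound 1 to compound 2 and a 1.0-fold higher number (0.02 log units; within the scatter) from compound 3 to compound 4, 14-fold (1.15 log units) apart, beyond the scatter of two such steps. This shows that the step cannot be transferred as a fixed amount in this series, but it does not show what sets the two steps apart, for they differ both in the core and in the place of the methoxy on the aromatic ring, and with one step on each core these two differences cannot be separated.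

The compounds shown leave open how a methoxy at the other place would behave on each of the two cores, which would tell core and place apart. They also leave open whether a hydroxyl or a fluorine on the same aromatic carbon would follow the methoxy.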